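Chloro for Fluoro: Expected Effect on Growth Inhibition

The source may report more compounds than this note shows. Statements on the series, on what has been measured and on what is new or still open speak of the compounds shown alone.

Measured compounds:
Compound 1, `N=C(N)c1ccc(-c2ccc(-c3cncc4ccccc34)s2)s1`, 1620 nM
Compound 2, `N=C(N)c1ccc(-c2ccc(-c3ccc(F)cc3)o2)o1`, 1230 nM

In a functional assay on M14 cells (Homo sapiens) for inhibition, read by sulforhodamine B assay, with a stated time of 48 h (on this read-out lower numbers stand for stronger inhibition of growth and higher numbers for weaker inhibition of growth), compound 1 gives 1620 nM. In this assay compound 2 gives 1230 nM, the lower of the two numbers, yet its gap from compound 1 stays within the scatter of repeat measurements, so the two cannot be told apart. Compound 3 (`N=C(N)c1ccc(-c2ccc(-c3ccc(Cl)cc3)o2)o1`) differs from compound 2 by chloro in place of fluoro on an aromatic carbon. Among the compounds with values here, no pair of measured compounds shows what this change does, so a step of no more than the scatter is expected, in either direction. The estimate for compound 3 in this assay is 1000 nM, within 400 nM to 2500 nM. This expectation corresponds to a step of a 1.2-fold lower number from compound 2 to compound 3 (0.09 log units; within the scatter).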

Compound 3, concentration for 50% growth inhibition: 1850 nM
Beside the measured number, compound 3's estimate is 1.9-fold (0.27 log units) below it, and the stated range covers the measured number.
By their numbers in this assay, from the lowest: compounds 2, 1 and 3 (each within the scatter of the next).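

Within the data shown here, the first measured pair for this change gives a 1.5-fold higher number from compound 2 to compound 3 (0.18 log units; within the scatter) in this assay, so fluoro and chloro cannot be told apart at this place on the ring, para to a large group. At this position, then, one halogen can stand in for the other without a step beyond the usual scatter. No measurement at hand bears on this result.

On these data alone, whether an amine or a carboxylic acid at this position would shift growth inhibition beyond the scatter stays open. So does whether this change would behave the same way on the core of compound 1.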